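The source may report more compounds than this note shows. Statements on the series, on what has been measured and on what is new or still open speak of the compounds shown alone.

Measured compounds:
Compound 1, `CC(C)(C)c1ccc(CNCCCNS(=O)(=O)c2cc(C(F)(F)F)cc(C(F)(F)F)c2)cc1`: 2000 nM
Compound 2, `O=S(=O)(NCCNCc1ccc(-c2ccccc2)cc1)c1cc(C(F)(F)F)cc(C(F)(F)F)c1`: 2700 nM
Compound 3, `O=S(=O)(NCCCNCc1ccc(-c2ccccc2)cc1)c1cc(C(F)(F)F)cc(C(F)(F)F)c1`: 2300 nM

All three were examined in a functional assay on HT-29 cells (Homo sapiens) for inhibition, read by MTT assay, with a stated time of 72 h; on this read-out lower numbers stand for stronger inhibition of growth and higher numbers for weaker inhibition of growth. Compound 1 and compound 3 share a core and differ in one place only: tert-butyl in place of phenyl on an aromatic carbon. This change made the step of a 1.2-fold lower number from compound 3 to compound 1 (0.06 log units; within the scatter), so the two compounds cannot be told apart on this read-out. Compound 2 and compound 3 differ from each other as well, but the difference between these two cores is not broken down here; compound 2 gives 2700 nM and compound 3 gives 2300 nM, and the two numbers lie within the scatter of each other, so no order between them can be claimed.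

Compound 4, `CC(C)(C)c1ccc(CNCCNS(=O)(=O)c2cc(C(F)(F)F)cc(C(F)(F)F)c2)cc1`, has not yet been measured in this assay. It stands to compound 2 as compound 1 stands to compound 3: the change is tert-butyl in place of phenyl on an aromatic carbon, the same change made on the other core, with the same surroundings at the place. Because that change gave a 1.2-fold lower number from compound 3 to compound 1 (0.06 log units; within the scatter) on the core of compound 3, the step from compound 2 to compound 4 is expected to be of the same small size, a 1.2-fold lower number from compound 2 to compound 4 (0.07 log units; within the scatter). On that basis compound 4 is estimated to give 2300 nM in this assay, most likely between 1200 nM and 4500 nM, which would leave it indistinguishable from compound 2 within the usual scatter.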

Compound 4, concentration for 50% growth inhibition: 14000 nM
Compound 4: middle estimate off by 6.1-fold (0.78 log units), on the low side; the measured number lies above the stated range.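

On the core of compound 2, tert-butyl in place of phenyl on an aromatic carbon gave a 5.2-fold higher number from compound 2 to compound 4 (0.71 log units; beyond the scatter) in this assay, whereas the same change on the other core gave a 1.2-fold lower number from compound 3 to compound 1 (0.06 log units; within the scatter). Set side by side, the two steps show that the effect of this change cannot be carried from one core to the other in this series, even with the same surroundings at the place: the same change on two cores in this assay, a 1.2-fold lower number (0.06 log units; within the scatter) from compound 3 to compound 1 and a 5.2-fold higher number (0.71 log units; beyond the scatter) from compound 2 to compound 4, 6.0-fold (0.78 log units) apart, beyond the scatter of two such steps What this does not show is why the two cores part ways, or whether either step is the more typical, since each core offers only a single pair and two pairs establish no rule for the series.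

The compounds shown leave open how other groups on that aromatic carbon, such as a cyclohexyl group or a chlorine atom, would behave on each of the two cores, and whether they would show the same split. They also leave open whether a longer chain in the linker would follow the core of compound 1 or that of compound 4 when phenyl gives way to tert-butyl.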